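Moving the Chlorine on an Unmeasured Analogue

The compounds below may be only part of what the source reports. "The series", "measured", "known", "first", "only" and "open" are said of these compounds alone.

In a functional assay on K562 cells (Homo sapiens) for inhibition, read by fluorescence, with a stated time of 72 h (a lower number here means a stronger inhibitor of growth, a higher number a weaker inhibitor of growth), the three measured compounds stand as follows: compound 1 `CC(C)CCn1cnc2c(Nc3ccc(Cl)cc3)nc(N[C@H]3CC[C@H](N)CC3)nc21` gives 1800 nM; compound 2 `CC(C)CCn1cnc2c(Nc3cccc(Cl)c3)nc(N[C@H]3CC[C@H](N)CC3)nc21` gives 1500 nM; compound 3 `CCCCn1cnc2c(Nc3ccc(Cl)cc3)nc(N[C@H]3CC[C@H](N)CC3)nc21` gives 2700 nM.

Compound 1 and compound 3 differ in their cores by hydrogen in place of methyl on a saturated chain carbon bound to two saturated chain carbons, a change that gave a 1.5-fold higher number from compound 1 to compound 3 (0.18 log units; within the scatter). Compound 4 `CCCCn1cnc2c(Nc3cccc(Cl)c3)nc(N[C@H]3CC[C@H](N)CC3)nc21` has not yet been measured in this assay. It differs from compound 3 by 3-chlorophenyl in place of 4-chlorophenyl on a nitrogen on an aromatic ring. The same change, made once before among these compounds, reads 3-chlorophenyl in place of 4-chlorophenyl on a nitrogen on an aromatic ring and gave a 1.2-fold lower number from compound 1 to compound 2 (0.08 log units; within the scatter). Since that earlier step stayed within the scatter, compound 4 is expected to show a step of similar size, a 1.2-fold lower number from compound 3 to compound 4 (0.08 log units; within the scatter), in this assay. The estimate for compound 4 is accordingly 2250 nM, with a likely range from 1100 nM to 4500 nM.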

Compound 4, concentration for 50% growth inhibition: 2000 nM
The estimate for compound 4 lay 1.1-fold (0.05 log units) above the measured number, and the stated range covers the measured number.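

Set on the second core, 3-chlorophenyl in place of 4-chlorophenyl gave a 1.4-fold lower number from compound 3 to compound 4 (0.13 log units; within the scatter), which agrees with the earlier step: the same change on two cores in this assay, a 1.2-fold lower number (0.08 log units; within the scatter) from compound 1 to compound 2 and a 1.4-fold lower number (0.13 log units; within the scatter) from compound 3 to compound 4, 1.1-fold (0.05 log units) apart, within the scatter of two such steps

Hydrogen in place of methyl on the chain gave a 1.3-fold higher number from compound 2 to compound 4 (0.12 log units; within the scatter), and this too agrees with its earlier counterpart: the same change on two cores in this assay, a 1.5-fold higher number (0.18 log units; within the scatter) from compound 1 to compound 3 and a 1.3-fold higher number (0.12 log units; within the scatter) from compound 2 to compound 4, 1.1-fold (0.05 log units) apart, within the scatter of two such steps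

Going by these compounds alone, all of these steps lie within the scatter, so the agreement shows only that neither change measurably moved the number on either core; it does not show that a larger effect would carry across, and two cores cannot establish a rule for the series.

The compounds shown leave open what a 3-methoxyphenyl group in place of the chlorophenyl groups would do in this assay. They also leave open the effect of a longer chain.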